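Chloro in Place of Methyl on Compound 2

The source may hold more compounds than are shown below. What is called first, only, known or untested is meant among the compounds shown, and "the series" means these compounds.

Compound 2 `CCCC(Oc1cnn(-c2cccc(C)c2)c1)c1ccc(C(=O)NCCC(=O)O)cc1`: 1110 nM
Compound 1 `CCCC(Oc1cnn(-c2ccc(C(F)(F)F)cn2)c1)c1ccc(C(=O)NCCC(=O)O)cc1`: 1190 nM

In an assay on isolated protein for displacement of a labelled ligand from Glucagon receptor (Homo sapiens) (a lower number here means a stronger inhibitor, a higher number a weaker inhibitor), compound 2 gives 1110 nM, and compound 1 gives 1190 nM; the two numbers lie within the scatter of each other, as a 1.1-fold lower number from compound 1 to compound 2 (0.03 log units; within the scatter) shows. Compound 3 `CCCC(Oc1cnn(-c2cccc(Cl)c2)c1)c1ccc(C(=O)NCCC(=O)O)cc1` differs from compound 2 by chloro in place of methyl on an aromatic carbon. Among the compounds with values here, no measured step touches this position: the only step, a 1.1-fold lower number from compound 1 to compound 2 (0.03 log units; within the scatter), swapped the whole aryl group on the nitrogen and stayed within the scatter. For compound 3 no change beyond the scatter is expected, so the estimated step is a 1.1-fold lower number from compound 2 to compound 3 (0.05 log units; within the scatter). Compound 3 is therefore estimated at 1000 nM, within a range of 400 nM to 2500 nM.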

Compound 3, inhibition constant: 1090 nM
For compound 3 the middle estimate is 1.1-fold (0.04 log units) below the measured one; measured number inside the range.
By their numbers in this assay, from the lowest: compounds 3, 2 and 1 (each within the scatter of the next).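

In this assay, chloro and methyl on this aromatic carbon cannot be told apart (a 1.0-fold lower number from compound 2 to compound 3 (0.01 log units; within the scatter)), which is a direct comparison at this position that the earlier step, a change of the whole aryl group, could not give. The 3-chlorophenyl and 5-(trifluoromethyl)pyridin-2-yl groups on the aromatic nitrogen also cannot be told apart (a 1.1-fold lower number from compound 1 to compound 3 (0.04 log units; within the scatter)). No available evidence bears on this result.

On these data alone, it remains open whether an amine or a nitrile on this aromatic carbon would give a number beyond the scatter.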